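Bromination of a coumarin thioether on two nucleoside cores

A few compounds are considered here, and "the series" means these few. Any claim that something is new, unique, unknown or untested is made for them only; others in the source may bear on it.

The study compares two families that share a coumarin thioether arm on a nucleoside-like scaffold. Compound 1 `CC(=O)OC[C@H]1O[C@@H](n2c(SCc3cc4ccccc4oc3=O)nc3cncnc32)[C@H](OC(C)=O)[C@@H]1OC(C)=O` carries a fully acetylated sugar, and in a functional assay on Huh-5-2 cells (Homo sapiens) for cytotoxicity, read by microscopy (a higher number here means that more compound is tolerated, a lower number that less compound is tolerated), compound 1 gives 39000 nM. Compound 2 `CC(=O)OC[C@H]1O[C@@H](n2c(SCc3cc4cc(Br)ccc4oc3=O)nc3cncnc32)[C@H](OC(C)=O)[C@@H]1OC(C)=O` differs from compound 1 only by the change (bromo in place of hydrogen on an aromatic carbon), and in this assay compound 2 gives 6700 nM, so the change made a 5.8-fold lower number from compound 1 to compound 2 (0.76 log units; beyond the scatter). Compound 3 `Nc1ncnc2c1nc(SCc1cc3ccccc3oc1=O)n2[C@@H]1O[C@H](CO)[C@@H](O)[C@H]1O` has an unprotected sugar and an amino-substituted core; the difference between the core of compound 1 and the core of compound 3 is not broken down here. In this assay compound 3 gives 49000 nM, which lies within the scatter of the value of compound 1 and is well separated from that of compound 2.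

Compound 4 `Nc1ncnc2c1nc(SCc1cc3cc(Br)ccc3oc1=O)n2[C@@H]1O[C@H](CO)[C@@H](O)[C@H]1O` is not yet measured. It differs from compound 3 by the change (bromo in place of hydrogen on an aromatic carbon), the same change that turned compound 1 into compound 2, at the same place on the ring. Because of the step of a 5.8-fold lower number from compound 1 to compound 2 (0.76 log units; beyond the scatter), the account expects a similar drop from compound 3 to compound 4 in this assay, estimated as a 5.4-fold lower number from compound 3 to compound 4 (0.74 log units; beyond the scatter), since compound 3 and compound 1 start from values within the scatter of each other. The estimate for compound 4 in this assay is 9000 nM, with an expected range from 3000 nM to 30000 nM.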

Compound 4, half-maximal cytotoxic concentration: 41000 nM
For compound 4 the middle estimate is 4.6-fold (0.66 log units) below the measured one, and the stated range ends below it.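

In this assay, bromo in place of hydrogen on the aromatic carbon gives a 1.2-fold lower number from compound 3 to compound 4 (0.08 log units; within the scatter), a step that cannot be told from no change at all, so the drop seen on the acetylated core does not reappear on the core of compound 3, and the two steps disagree: the same change on two cores in this assay, a 5.8-fold lower number (0.76 log units; beyond the scatter) from compound 1 to compound 2 and a 1.2-fold lower number (0.08 log units; within the scatter) from compound 3 to compound 4, 4.9-fold (0.69 log units) apart, beyond the scatter of two such steps Within this series, then, the step measured on one core cannot be carried over as a fixed increment to the other, and it held for only one of the two pairs shown. Within the data shown here, this does not show which feature of the two cores separates the steps, as compound 1 and compound 3 differ both in the sugar and in the amino substituent on the core, and each core contributes only a single pair.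

The compounds shown leave open whether the acetyl groups on the sugar or the amino group on the core decides the outcome, which a pair carrying only one of those two differences could separate. They also leave open whether a chloro or a methoxy group at the same place on the ring would follow the bromo group on either core.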